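Diaryl ether in place of substituted biaryl on the shared core

The source may report more compounds than this note shows. Statements on the series, on what has been measured and on what is new or still open speak of the compounds shown alone.

Compound 1 `CC(C)c1ccccc1-c1cccc(COc2ccc(S(=O)(=O)CC(=O)O)cc2)c1` gives 74.1 nM in a functional assay on CHO cells for agonist activity at Free fatty acid receptor 1 (Homo sapiens), read by FLIPR and calcium flux; on this read-out lower numbers stand for an effect already at smaller amounts and higher numbers for an effect only at larger amounts of compound. Compound 2 `Cc1ccc(-c2cccc(COc3ccc(S(=O)(=O)CC(=O)O)cc3)c2)c(Cl)c1` gives 36.3 nM. Compound 3 `CCOc1ccc(-c2cccc(COc3ccc(S(=O)(=O)CC(=O)O)cc3)c2)c(Cl)c1` gives 51.3 nM.

Compound 3 sits second highest of the three numbers, its nearest neighbour being compound 2 and its furthest compound 1. Compound 4 `O=C(O)CS(=O)(=O)c1ccc(OCc2cccc(Oc3ccccc3)c2)cc1` differs from compound 3 by phenoxy in place of 2-chloro-4-ethoxyphenyl on an aromatic carbon. The measured steps all alter only the distal ring and are small: a 2.0-fold lower number from compound 1 to compound 2 (0.31 log units; beyond the scatter), a 1.4-fold lower number from compound 1 to compound 3 (0.16 log units; within the scatter) and a 1.4-fold higher number from compound 2 to compound 3 (0.15 log units; within the scatter). Among the measured compounds shown here, no measured step replaces the aryl by an aryloxy group, so the step to compound 4 is not directly covered. Compound 4 is expected to give a somewhat higher number, a 2.9-fold higher number from compound 3 to compound 4 (0.47 log units; beyond the scatter), estimated at 150 nM within 40 nM to 600 nM.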

Compound 4, half-maximal effective concentration: 97.7 nM
For compound 4 the middle estimate is 1.5-fold (0.19 log units) above the measured one; the range from low to high includes it.
By their numbers in this assay, from the lowest: compounds 2, 3, 1 and 4 (each within the scatter of the next, the first and the last beyond it).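

Among the compounds shown here, at this position on an aromatic carbon, phenoxy is the first group in this assay that is not a substituted phenyl, and it carries neither chloro nor isopropyl. For the compounds shown here, it is not separated from two of the earlier groups, with a 1.9-fold higher number from compound 3 to compound 4 (0.28 log units; within the scatter) and a 1.3-fold higher number from compound 1 to compound 4 (0.12 log units; within the scatter), and only the step to the 2-chloro-4-methylphenyl compound is clear, with a 2.7-fold higher number from compound 2 to compound 4 (0.43 log units; beyond the scatter). Nothing measured here explains these differences. Still open, going by these compounds, is how an amine or a nitrile on the phenoxy ring would read in this assay.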